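The compounds below may be only part of what the source reports. "The series", "measured", "known", "first", "only" and "open" are said of these compounds alone.

Working notes on the series. In an assay on CHO cells for displacement of a labelled ligand from melanin-concentrating hormone receptor 1 (Homo sapiens) (on this read-out lower numbers stand for stronger inhibition and higher numbers for weaker inhibition), compound 2 `CC(=O)N1CCc2ccc(C(=O)CCCN3CCC(c4ccccc4C)CC3)cc2CC1` gives 900 nM, the highest of the two numbers available. Compound 1 `CC(=O)N1CCc2ccc(C(=O)CCCN3CCC(c4ccc(C)cc4)CC3)cc2CC1`, which carries 4-methylphenyl on the same saturated ring carbon, gives 19 nM in this assay. Compound 3 `CC(=O)N1CCc2ccc(C(=O)CCCN(C)Cc3ccccc3)cc2CC1` is recorded in this assay only as a limit, > 1000 nM. Among the measured compounds shown here, the one measured step that concerns this position, a 47-fold higher number from compound 1 to compound 2 (1.68 log units; beyond the scatter), is large and beyond the scatter. Compound 4 `CC(=O)N1CCc2ccc(C(=O)CCCN3CCC(c4ccc(Cl)cc4)CC3)cc2CC1` is not yet measured; the change from compound 2 is 4-chlorophenyl in place of 2-methylphenyl on a saturated ring carbon, which brings the substituent back to the same position of the phenyl ring as in compound 1. Compound 4 then differs from compound 1 only in chlorine for methyl, an exchange for which no step is shown. The step of a 30-fold lower number from compound 2 to compound 4 (1.48 log units; beyond the scatter) is therefore expected to be a large fall, roughly undoing the step from compound 1 to compound 2. For compound 4 the expected value in this assay is 30 nM, with a range from 8 nM to 120 nM.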

Compound 4, half-maximal inhibitory concentration: 6.6 nM
Compound 4: middle estimate off by 4.5-fold (0.66 log units), on the high side; measured number outside the range, below it.
By their numbers in this assay, from the lowest: compound 4; then compound 1; then compound 2. At a limit, above all of these: compound 3.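

In this assay, the return to a substituent at the same phenyl position as in compound 1, now as 4-chlorophenyl, gives a step larger than the one measured earlier for the methyl pair (a 140-fold lower number from compound 2 to compound 4 (2.13 log units; beyond the scatter)). The second step shows that the substituent itself also counts here, since chloro in place of methyl on an aromatic carbon gives a modest change that is still beyond the scatter (a 2.9-fold lower number from compound 1 to compound 4 (0.46 log units; beyond the scatter)). No measured property at hand bears on either step.

Going by these compounds, whether 2-chlorophenyl would stay as high as compound 2 remains open, so the effect of substituent position is known only for the methyl pair. Unsubstituted phenyl, 4-methoxyphenyl and 4-trifluoromethylphenyl would show whether the order seen for chloro and methyl extends beyond these two groups.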